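Sigma-1 binding of aryl-chromenone amines: a methoxy shift

The compounds below may be only part of what the source reports. "The series", "measured", "known", "first", "only" and "open" are said of these compounds alone.

Measured compounds:
compound 1, `O=c1cc(-c2ccccc2)oc2cccc(OCCCCN3CCC(O)CC3)c12`, 58 nM
compound 2, `CN(CCCCCCOc1ccc2oc(-c3ccccc3)cc(=O)c2c1)Cc1ccccc1`, 52 nM
compound 3, `COc1cccc(-c2cc(=O)c3cc(OCCCCCCN4CCC(O)CC4)ccc3o2)c1`, 76 nM

All three compounds were read in an assay on isolated protein (Cavia porcellus) with Sigma non-opioid intracellular receptor 1 (Homo sapiens) as the target, read by radioligand binding; on this read-out higher numbers stand for weaker inhibition and lower numbers for stronger inhibition. Compound 1 gives 58 nM, compound 2 gives 52 nM, and compound 3 gives 76 nM. Compound 3 is nominally the largest of the three numbers, but its gap to compound 1 and its gap to compound 2 both fall within the usual scatter of repeated measurements, so the three compounds are indistinguishable on this read-out. Going by the values given here, no pair among them differs in a single place, so no single-point step is available from the measured set.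

Compound 4, `COc1ccc(-c2cc(=O)c3cc(OCCCCCCN4CCC(O)CC4)ccc3o2)cc1`, has not yet been measured in this assay. It differs from compound 3 only in 4-methoxyphenyl in place of 3-methoxyphenyl on an aromatic carbon. Among the compounds with values here, with no measured step of this kind to lean on, the expected change from compound 3 to compound 4 is none beyond the scatter, the estimated step being a 1.2-fold lower number from compound 3 to compound 4 (0.07 log units; within the scatter). Compound 4 is therefore estimated at 65 nM in this assay, with a range from 20 nM to 200 nM.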

Compound 4, half-maximal inhibitory concentration: 254 nM
The estimate for compound 4 lay 3.9-fold (0.59 log units) below the measured number, and the stated range ends below it.
By their numbers in this assay, from the lowest: compounds 2, 1 and 3 (each within the scatter of the next); then compound 4.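

In this assay, exchanging 3-methoxyphenyl for 4-methoxyphenyl on this aromatic carbon gives a 3.3-fold higher number from compound 3 to compound 4 (0.52 log units; beyond the scatter), so this position responds to where the methoxy group stands on the phenyl ring. The earlier compounds shown here could not show this: they stood within the scatter of one another and offered no step that changed a single place. The two groups have the same atoms and the same counts of rings, donors and acceptors, so the difference between compound 3 and compound 4 lies in how those atoms are joined, not in what is added or removed. No measured property or other evidence at hand accounts for the size of this step.

A single step at one position leaves open whether an ethoxy group, a hydroxyl group or a fluorine in place of the methoxy group would follow compound 4 or compound 3 in this assay. It also leaves open whether the same exchange would give a step of similar size with a longer chain or with a dimethylamine at the chain end.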